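Shrinking the ring on the ether-linked carbon

The source may report more compounds than this note shows. Statements on the series, on what has been measured and on what is new or still open speak of the compounds shown alone.

Three compounds share one core and differ only in the group on the saturated chain carbon bound to an oxygen on an aromatic ring. Compound 1 `CC(C)(C)Sc1c(CC(C)(C)C(=O)O)n(Cc2ccc(Cl)cc2)c2ccc(OCc3cc4ccccc4cn3)cc12` gives 3 nM in a functional assay for inhibition, with Homo sapiens as the target; on this read-out lower numbers stand for stronger inhibition and higher numbers for weaker inhibition. Compound 2 `CC(C)(C)Sc1c(CC(C)(C)C(=O)O)n(Cc2ccc(Cl)cc2)c2ccc(OCc3ccc4cccnc4n3)cc12` gives 6 nM in this assay, and compound 3 `CC(C)(C)Sc1c(CC(C)(C)C(=O)O)n(Cc2ccc(Cl)cc2)c2ccc(OCc3ccncc3)cc12` gives 6 nM, level with compound 2 at the digits shown and together the highest of the three numbers; the step between the first two shows a 2.0-fold higher number from compound 1 to compound 2 (0.30 log units; within the scatter). The change to compound 4 `CC(C)(C)Sc1c(CC(C)(C)C(=O)O)n(Cc2ccc(Cl)cc2)c2ccc(OCc3cnccn3)cc12` is a group of 6 heavy atoms (4 carbon, 2 nitrogen; one six-membered aromatic ring with 2 hetero atoms) in place of a group of 10 heavy atoms (8 carbon, 2 nitrogen; 2 six-membered aromatic rings with 1 hetero atom each), on a saturated chain carbon bound to an oxygen on an aromatic ring. Among the measured compounds shown here, the steps that bear on it, no change at the digits printed from compound 2 to compound 3 (within the scatter) and a 2.0-fold higher number from compound 1 to compound 3 (0.30 log units; within the scatter), both stayed within the scatter, so in this assay no step beyond the scatter is expected, in either direction. Compound 4 is therefore estimated at 6 nM, between 2.5 nM and 15 nM, which means an expected no change at the digits printed from compound 2 to compound 4 (within the scatter).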

Compound 4, half-maximal inhibitory concentration: 4 nM
Estimate against measurement, compound 4: 1.5-fold (0.18 log units) above; the measured number falls inside the stated range.
By their numbers in this assay, from the lowest: compounds 1, 4, 2 and 3 (each within the scatter of the next).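

In this assay, pyrazin-2-yl on this saturated chain carbon stays within the scatter of all three earlier groups: a 1.5-fold lower number from compound 2 to compound 4 (0.18 log units; within the scatter), a 1.5-fold lower number from compound 3 to compound 4 (0.18 log units; within the scatter) and a 1.3-fold higher number from compound 1 to compound 4 (0.12 log units; within the scatter). The position therefore accepts one six-membered aromatic ring with 2 hetero atoms with no step beyond the scatter, just as it does the single-hetero-atom pyridin-4-yl and the larger two-ring groups. No further data bearing on this result are available. As far as these compounds go, all four groups are aromatic rings containing nitrogen, so it remains open whether a plain phenyl ring, a saturated amine such as piperidine or a carboxylic acid here would also stay within the scatter.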